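The source may report more compounds than this note shows. Statements on the series, on what has been measured and on what is new or still open speak of the compounds shown alone.

Compounds measured so far:
Compound 1 `CCn1c(CNc2ccccc2)nnc1SCc1nc2cc(C(=O)C(C)C)ccc2o1` — 520 nM in an assay on isolated protein for inhibition of long-chain fatty acid transport protein 1 (Mus musculus); a higher number here means a weaker inhibitor, a lower number a stronger inhibitor
Compound 2 `CCn1c(CNc2ccccc2)nnc1SCc1nc2cc(F)ccc2o1` — 7800 nM in this assay

Compound 2 stands at the highest of the two numbers, with compound 1 lower by a 15-fold higher number from compound 1 to compound 2 (1.18 log units; beyond the scatter). Compound 3 `CC/C(=N/OC)c1ccc2oc(CSc3nnc(CNc4ccccc4)n3CC)nc2c1` differs from compound 2 in that (a group of 6 heavy atoms (4 carbon, 1 nitrogen, 1 oxygen; no ring) in place of one fluorine atom, on an aromatic carbon). Within the data shown here, the one step that bears on this is the change from compound 1 to compound 2, where a 15-fold higher number from compound 1 to compound 2 (1.18 log units; beyond the scatter) accompanied the loss of a carbonyl-bearing substituent at the same aromatic carbon. Since compound 3 restores a larger, acceptor-bearing group there, its number is expected to fall, by about an 8.7-fold lower number from compound 2 to compound 3 (0.94 log units; beyond the scatter). Compound 3 is therefore estimated at 900 nM, in the range 250 nM to 3000 nM.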

Compound 3, half-maximal inhibitory concentration: > 10000 nM
Compound 3 ended at the assay's limit; the forecaster's own chance of this, stated with the estimate: 3%; at least 11-fold (1.04 log units) between middle value and limit.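

In this assay compound 3 gives > 10000 nM, which is a limit of the assay. Replacing the group on this aromatic carbon gives an at least 19-fold higher number from compound 1 to compound 3 (1.28 log units; beyond the scatter), so a group of 6 heavy atoms does not keep the low number of compound 1, and a larger group here does not by itself lower it. Against fluoro, the result is an at least 1.2-fold higher number from compound 2 to compound 3 (0.10 log units; that floor lies within the scatter), so no order can be set between these two compounds.

The compounds shown leave open how much of the low number of compound 1 depends on its carbonyl and how much on its isopropyl part. A methyl ketone or a primary amide on this carbon would separate the two.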